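Piperidinyl for methoxyethylamino on two related cores

The source may hold more compounds than are shown below. What is called first, only, known or untested is meant among the compounds shown, and "the series" means these compounds.

Of the compounds shown here, three have been measured in an assay on isolated protein for inhibition of RAC-alpha serine/threonine-protein kinase (Homo sapiens), read by mobility shift assay, tested at 30 uM; a higher number here means more inhibition at the concentration tested (going by the name of the read-out), a lower number less inhibition. Compound 1 `Cc1cc2c(c(N)nn2C)c(N2CCCCC2)n1` gives 6% in this assay. Compound 2 `COCCNc1nc(C)cc2c1c(N)nn2C` gives 6% in this assay. Compound 3 `COCCNc1nc(C)cc2nn(-c3ccccc3)c(N)c12` gives 3% in this assay. All three numbers lie within the usual scatter of one another, so no order among them can be read from these data.

One single-point change is covered by measured pairs. From compound 2 to compound 1 the change is piperidin-1-yl in place of (2-methoxyethyl)amino on an aromatic carbon and the step in this assay is no change at the digits printed from compound 2 to compound 1 (within the scatter). The core of compound 3 differs from the core of compound 2 in more than one place; that difference is not broken down here.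

Compound 4 `Cc1cc2nn(-c3ccccc3)c(N)c2c(N2CCCCC2)n1` has not been measured. It arises from compound 3 by piperidin-1-yl in place of (2-methoxyethyl)amino on an aromatic carbon. Within the data shown here, the surroundings of the exchanged group are described in the same words for both pairs, so this is the same change as the one from compound 2 to compound 1. On that measured step, the step expected from compound 3 to compound 4 is a number 1 percentage points higher from compound 3 to compound 4 (within the scatter), beside the earlier one, because no change at the digits printed from compound 2 to compound 1 (within the scatter) showed no movement beyond the scatter. For compound 4 the expected value in this assay is 4%, with a likely range from -6% to 14%.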

Compound 4, a percentage reported as inhibition, at one concentration (the size of the read-out at that concentration, not a potency): 1%
Compound 4: middle estimate off by 3 percentage points, on the high side, and the stated range covers the measured number.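

In this assay the exchange of (2-methoxyethyl)amino for piperidin-1-yl on the core of compound 3 gives a number 2 percentage points lower from compound 3 to compound 4 (within the scatter), and the two cores do not differ in how they take this change: the same change on two cores in this assay, no change at the digits printed (within the scatter) from compound 2 to compound 1 and a number 2 percentage points lower (within the scatter) from compound 3 to compound 4, 2 percentage points apart, within the scatter of two such steps

On these two cores, then, the exchange moves the number no further than the scatter, and the earlier step carries over to the second core only in that sense. This does not show that the change is without effect in general: compound 2 gives 6% and compound 3 gives 3%, both little inhibition at the one concentration tested, so the agreement is between two steps without measurable size and says nothing about how the change would carry to a core that starts from clear inhibition.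

Open, as far as these compounds go, is whether any group on that aromatic carbon lifts the number at all, for example an aliphatic amine with a free amino end, a carboxylic acid or a longer ether chain in place of (2-methoxyethyl)amino. Also open, from the compounds shown here alone, is whether the exchange would keep its null step on a core carrying something other than the methyl group, such as a chloro or a methoxy group.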